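Replacing the urea of compound 2 with an amide

The source may hold more compounds than are shown below. What is called first, only, known or untested is meant among the compounds shown, and "the series" means these compounds.

Measured compounds and values:
compound 1 `COc1cc(Nc2ncnc3c(NC(=O)Nc4cc(Cl)cc(Cl)c4)cccc23)cc(OC)c1` gives 30.2 nM
compound 3 `COc1cc(Nc2ncnc3c(NC(=O)Nc4cccc(Cc5ccccc5)c4)cccc23)cc(OC)c1` gives 1740 nM
compound 2 `COc1cc(Nc2ncnc3c(NC(=O)Nc4ccc([N+](=O)[O-])cc4)cccc23)cc(OC)c1` gives only a limit, > 20000 nM

All three are ureas on the shared core, read in a functional assay on RT-112 cells (Homo sapiens) for antiproliferative activity, read by MTT assay, with a stated time of 72 h; a higher number here means a weaker inhibitor of growth, a lower number a stronger inhibitor of growth. Compound 2 stands at the limit of > 20000 nM in this assay, at which 1 of the 3 values shown sits; its value is a limit of the assay and not a number. For the measured compounds named here, the only measured step that touches compound 2 is an at least 660-fold higher number from compound 1 to compound 2 (2.82 log units; beyond the scatter), a change of the aryl group on an amide-type nitrogen. Compound 3, with a further aryl urea, lies between the two on the numbers shown.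

Compound 4 `COc1cc(Nc2ncnc3c(NC(=O)c4ccc(CN(C)C)cc4)cccc23)cc(OC)c1` differs from compound 2 by 4-((dimethylamino)methyl)phenyl in place of (4-nitrophenyl)amino on a carbonyl carbon. Going by the values given here, no measured step covers this change: the step from compound 1 to compound 2 swaps one aryl group for another on the amide-type nitrogen, whereas here that nitrogen leaves together with its aryl group and a carbon-linked aryl group enters. The direction can be read only from where compound 2 stands: at a limit, so any number the assay reports would be a lower one. Compound 4 is expected to give 3000 nM, within 300 nM to 20000 nM, which is estimated as an at least 6.6-fold lower number from compound 2 to compound 4 (0.82 log units; beyond the scatter), with a real chance that the assay again reports only a limit.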

Compound 4, concentration for 50% growth inhibition: 4370 nM
Beside the measured number, compound 4's estimate is 1.5-fold (0.16 log units) below it; the range from low to high includes it.
By their numbers in this assay, from the lowest: compound 1; then compound 3; then compound 4. At a limit, above all of these: compound 2.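

An amide on this carbonyl carbon, without the urea's amide-type nitrogen and its aryl group, can still give a reportable number in this assay: 4-((dimethylamino)methyl)phenyl in place of (4-nitrophenyl)amino gives an at least 4.5-fold lower number from compound 2 to compound 4 (0.66 log units; beyond the scatter). The size of that step is only a lower bound, since compound 2 stands at a limit of the assay and not at a number: the limit of > 20000 nM in this assay, at which 1 of the 4 values shown sits.
Measured against the dichlorophenyl urea, the same amide loses much ground, with a 140-fold higher number from compound 1 to compound 4 (2.16 log units; beyond the scatter), so leaving the urea does not by itself bring a gain in this small set, and the recovery from compound 2 is only partial.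

Each step to compound 4 changes the linking atom and the aryl group together, so the share of each in these differences stays unresolved. A 3,5-dichlorophenyl group directly on the carbonyl carbon would address the linking atom with the aryl group held closer to that of compound 1, and a morpholine in place of the dimethylamino group would address the role of the amine.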